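The source may hold more compounds than are shown below. What is called first, only, known or untested is meant among the compounds shown, and "the series" means these compounds.

Measured compounds:
- Compound 1 `CC(=O)Nc1cnc2[nH]c(=O)n([C@H]3CC[C@@H](C(C)(C)C)CC3)c(=O)c2c1`: < 28000 nM (a limit, not a number)
- Compound 2 `CC[C@H]1CC[C@H](n2c(=O)[nH]c3ncc(NC(C)=O)cc3c2=O)CC1`: 22000 nM

The two compounds were tested in a physicochemical assay for solubility, read by nephelometry, measured as kinetic solubility; a higher number here means a more soluble compound, a lower number a less soluble compound. Going by the values given here, compound 2 gives 22000 nM, the only true number available in this assay. Compound 1 gives < 28000 nM, which is a limit of the assay. Among the compounds with values here, the account therefore has a single numerical anchor, and no measured step between two compounds can serve as a guide.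

The next compound is compound 3 `CC[C@H]1CC[C@@H](n2c(=O)[nH]c3ncc(NC(C)=O)cc3c2=O)CC1`, which has not yet been measured. Its difference from compound 2 is the two compounds have the same atoms and bonds and differ only in configuration as drawn: 2 of 2 stereo elements differ (all stereocentres are inverted: mirror images); a stereocentre at a saturated ring carbon is drawn r in compound 2 and s in compound 3; a stereocentre at a saturated ring carbon is drawn r in compound 2 and s in compound 3. Nothing leaves and nothing enters, so the two compounds share the same atoms and bonds and differ only in configuration as drawn.

Within the data shown here, with no measured step to draw on, the expectation rests on the value of compound 2 at 22000 nM and on the unchanged atoms and bonds. No step beyond the usual scatter is expected, and no direction is favoured, so the estimate is no change at the digits printed from compound 2 to compound 3 (within the scatter). For compound 3 the expected value is 22000 nM, with an estimated range from 11000 nM to 44000 nM.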

Compound 3, solubility: 48000 nM
The estimate for compound 3 lay 2.2-fold (0.34 log units) below the measured number; the measured number lies above the stated range.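

Going by these compounds alone, the step of a 2.2-fold higher number from compound 2 to compound 3 (0.34 log units; beyond the scatter) in this assay is the first number in this account that bears on the saturated ring carbons, and it shows that the read-out can move beyond the scatter with no group changing at all, the whole step resting on a single feature: the fact that compounds 2 and 3 differ only in the configuration as drawn. Compound 1 gives < 28000 nM, which is a limit of the assay and not a number: the limit of < 28000 nM in this assay, at which 1 of the 3 values shown sits. Set against that limit, ethyl in place of tert-butyl on a saturated ring carbon gives an at least 1.7-fold higher number from compound 1 to compound 3 (0.23 log units; that floor lies within the scatter), a floor that says little about the size of this change and does not show that the group matters to the read-out.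

With only ethyl and tert-butyl shown on that ring carbon, it remains open whether configuration would count for as much with another group there, such as a hydroxyl, a primary amine or a carboxylic acid. As far as these compounds go, the true value for compound 1 also remains open.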